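Working notes: from compound 2 to compound 4

This account rests on a few compounds, and the source may have more. Where it says the series, first, only, none or still open, it means among the compounds named here.

Values in an ADME assay for pharmacokinetics, read by LC-MS, in phosphate buffer, with a stated time of 120 min, at pH 7.4, tested at 1 uM, in the presence of a further agent that is not named here (a higher number here means that the compound lasts longer, a lower number that the compound disappears faster), for the measured compounds:
- compound 1 (`CN1CCN(C/C=C/C(=O)Nc2ccccc2)CC1`), a limit (> 8.53 h)
- compound 2 (`C/C=C/C(=O)Nc1ccccc1`), a limit (> 8.53 h)
- compound 3 (`CCN(CC)C/C=C/C(=O)Nc1ccccc1`), a number (2.83 h)

Compound 2 gives a limit (> 8.53 h) and not a number. It shares this position with one other compound (the limit of > 8.53 h in this assay, at which 2 of the 3 values shown sit).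

Compound 4 (`O=C(/C=C/C(F)F)Nc1ccccc1`) has difluoromethyl in place of methyl on a double-bonded chain carbon bound to a double-bonded chain carbon.

Among the measured compounds shown here, one measured step bears on this change: an at least 3.0-fold lower number from compound 2 to compound 3 (0.47 log units; beyond the scatter) with diethylamino in place of hydrogen on a saturated chain carbon bound to a double-bonded chain carbon. That step lies beyond the scatter. Compound 1 also gives a limit (> 8.53 h) and stands against any general fall in this series.

Going by compound 3 (2.83 h), a lower number of similar size is expected in this assay for the new group, though on thin evidence. The expected change is an at least 4.2-fold lower number from compound 2 to compound 4 (0.62 log units; beyond the scatter) in this estimate. Compound 4 is estimated at 2 h with an expected range from 0.5 h to 8 h for repeated measurements.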

Compound 4, half-life: 0.733 h
Beside the measured number, compound 4's estimate is 2.7-fold (0.44 log units) above it; measured number inside the range.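

Difluoromethyl in place of methyl on a double-bonded chain carbon bound to a double-bonded chain carbon gives, in this assay, an at least 11-fold lower number from compound 2 to compound 4 (1.06 log units; beyond the scatter). A fall beyond the scatter in this series therefore does not depend on an amine: the only earlier fall came with diethylamino, whereas difluoromethyl brings in only fluorine and no net charge. The true size of the step stays unknown, because compound 2 stands at a limit and not at a number: the limit of > 8.53 h in this assay, at which 2 of the 4 values shown sit.

As far as these compounds go, whether the fall follows the fluorine atoms or simply any replacement of methyl at this place stays open, and fluoromethyl, trifluoromethyl or ethyl there would separate these readings. The shared core also offers no test of whether the fall persists with a substituent such as chloro on the phenyl ring.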